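From a Phenoxy to a Carbamoyloxy Group

The compounds below may be only part of what the source reports. "The series", "measured", "known", "first", "only" and "open" are said of these compounds alone.

In a functional assay on V79-379A cells (Cricetulus griseus) for cytotoxicity, read by MTT assay, in the presence of a further agent that is not named here (a higher number here means a weaker inhibitor, a lower number a stronger inhibitor), three compounds with a shared core have been measured: compound 1 `COC1=CC(=O)c2c(c(COC(=O)c3ccc(F)cc3)c(C)n2C)C1=O` gives 300 nM, compound 2 `COC1=CC(=O)c2c(c(COc3ccccc3)c(C)n2C)C1=O` gives 700 nM and compound 3 `COC1=CC(=O)c2c(c(COc3cccc(NC(C)=O)c3)c(C)n2C)C1=O` gives 40 nM. Compound 2 therefore has the highest number of the three, and compound 1 is its nearest neighbour, with the gap beyond the scatter.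

Compound 4 `COC1=CC(=O)c2c(c(COC(N)=O)c(C)n2C)C1=O` departs from compound 2 by one change: carbamoyl in place of phenyl on an oxygen on a saturated carbon. The phenoxy group becomes carbamoyloxy.

Going by the values given here, the only measured step, an 18-fold lower number from compound 2 to compound 3 (1.24 log units; beyond the scatter), is large, but it adds acetamido and keeps the phenyl. Among the compounds with values here, it shows that changes in this part of the molecule can matter, yet it gives no direct guide, as no measured step removes the phenyl. Compound 1 also lacks the phenoxy group, carries a carbonyl on that oxygen and gives 300 nM, so a moderate drop in this assay seems likely.

The expected change is an estimated 2.3-fold lower number from compound 2 to compound 4 (0.37 log units; beyond the scatter). For compound 4 the estimated value is 300 nM, with an expected range of 70 nM to 1200 nM.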

Compound 4, half-maximal inhibitory concentration: 300 nM
Estimate against measurement, compound 4: no gap at the digits printed; the measured number falls inside the stated range.
By their numbers in this assay, from the lowest: compound 3; then compounds 1 and 4 (each within the scatter of the next); then compound 2.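

In this assay the phenyl on this oxygen proves not to be needed for activity: carbamoyl, a smaller group without a ring, gives a 2.3-fold lower number from compound 2 to compound 4 (0.37 log units; beyond the scatter) and the step is modest. Amino in place of 4-fluorophenyl on a carbonyl carbon gives no change at the digits printed from compound 1 to compound 4 (within the scatter) and so, among these two compounds with a carbonyl on that oxygen, the aromatic ring makes no visible difference. No evidence is available to explain either step.

Still open, going by these compounds, is what carbamoyl itself contributes, as dimethylamino in place of amino on the carbonyl carbon, or a plain hydroxyl in place of the whole carbamoyloxy group, could give a different number. Also open, on these data alone, is whether acetamido, which sits on the phenyl of compound 3 , would have any counterpart on these smaller groups.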